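The source may hold more compounds than are shown below. What is called first, only, known or untested is meant among the compounds shown, and "the series" means these compounds.

Measured so far:
compound 1, `CSc1c(C#N)c(N)c(C#N)c(-c2ccccc2)c1-c1ccccc1`, reported as "not active" (no number reported) in an assay on isolated protein for inhibition of glucose-6-phosphatase catalytic subunit 1 (Homo sapiens), tested at 100 uM (a lower number here means less inhibition, a higher number more inhibition at the concentration tested (going by the name of the read-out)), with no number given;
compound 2, `CSc1c(C)c(-c2ccccc2)c(C#N)c(N)c1C#N`, 45%;
compound 3, `COc1ccc(-c2c(C)c(SC)c(C#N)c(N)c2C#N)cc1`, 37.5%.

Among the two numbers available, compound 2 stands highest, but its nearest neighbour, compound 3, lies only a number 7.5 percentage points lower from compound 2 to compound 3 (within the scatter) away, a step within the scatter, so the two cannot be told apart. That step is methoxy in place of hydrogen on an aromatic carbon of the phenyl group, a different place from the one changed here.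

Compound 4, `Cc1c(-c2ccccc2)c(C#N)c(N)c(C#N)c1N1CCC(C)CC1`, has not yet been measured. It differs from compound 2 as follows: 4-methylpiperidin-1-yl in place of methylsulfanyl on an aromatic carbon. Going by the values given here, none of the measured steps touches the methylsulfanyl position, so nothing here shows how this assay responds to a change at that place. Among the compounds with values here, the one measured step, at another position, stayed within the scatter, which says nothing about a group of this kind.

With no guidance, the estimate for compound 4 starts from compound 2 and is widened: compound 4 is expected to give about 38%, between 5% and 65%. This corresponds to an expected step of a number 7 percentage points lower from compound 2 to compound 4 (within the scatter), with no direction that can be justified beyond the scatter.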

Compound 4, a percentage reported as inhibition, at one concentration (the size of the read-out at that concentration, not a potency): 2.3%
The estimate for compound 4 lay 35.7 percentage points above the measured number, outside the stated range (below it).
By their numbers in this assay, from the lowest: compound 4; then compounds 3 and 2 (each within the scatter of the next).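

The place on the shared core that holds methylsulfanyl in compound 2 clearly matters in this assay: putting 4-methylpiperidin-1-yl there gives a number 42.7 percentage points lower from compound 2 to compound 4 (beyond the scatter) in the read-out, and almost no inhibition remains at the concentration tested. Going by these compounds alone, the only earlier step between measured compounds, methoxy in place of hydrogen on the phenyl group, was a number 7.5 percentage points lower from compound 2 to compound 3 (within the scatter) and so showed no real change, which makes this the first evidence that a change to this series can shift the number beyond ordinary variation. Nothing given here explains why inhibition falls so sharply with this swap.

This single change alters several things at once, replacing a sulfur-linked group that has no ring with a nitrogen-linked six-membered non-aromatic ring, so the compounds shown cannot say which of these differences matters. As far as these compounds go, whether inhibition would hold with a small amine such as dimethylamino, a longer sulfur chain such as ethylsulfanyl, or a morpholin-4-yl ring at this position remains open.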